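Sigma-1 displacement series: hydroxyphenylpropyl amine replacing trifluoromethylbenzyl

The source may hold more compounds than are shown below. What is called first, only, known or untested is meant among the compounds shown, and "the series" means these compounds.

Compound 2 `Fc1ccc(C(SCCNC2CCN(Cc3ccc(C(F)(F)F)cc3)CC2)c2ccc(F)cc2)cc1` stands at the higher of the two numbers measured: in an assay on membranes from Cortex for displacement of a labelled ligand from Sigma non-opioid intracellular receptor 1 (Cavia porcellus), read by scintillation counting, with a stated time of 120 min (a higher number here means a weaker inhibitor, a lower number a stronger inhibitor), compound 2 gives 186 nM, while compound 1 `Fc1ccc(CN2CCC(NCCSC(c3ccc(F)cc3)c3ccc(F)cc3)CC2)cc1` gives 13.3 nM. For the measured compounds named here, the one step measured, a 14-fold higher number from compound 1 to compound 2 (1.15 log units; beyond the scatter), is large. Compound 3 `OC(Cc1ccccc1)CN1CCC(NCCSC(c2ccc(F)cc2)c2ccc(F)cc2)CC1` differs from compound 2 by 1-hydroxy-2-phenylethyl in place of 4-(trifluoromethyl)phenyl on a saturated chain carbon bound to an amine nitrogen in a ring. Going by the values given here, that removes the trifluoromethyl whose entry marked the step from compound 1 to compound 2, but also alters the link to the ring, for which no measured step exists. A drop in number is expected, a 5.3-fold lower number from compound 2 to compound 3 (0.73 log units; beyond the scatter), with wide uncertainty. Compound 3 is estimated at 35 nM, range 8 nM to 150 nM.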

Compound 3, inhibition constant: 309 nM
Estimate against measurement, compound 3: 8.8-fold (0.95 log units) below; the whole stated range lies below it.
By their numbers in this assay, from the lowest: compound 1; then compounds 2 and 3 (each within the scatter of the next).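

In this assay, 2-hydroxy-3-phenylpropyl and 4-(trifluoromethyl)benzyl cannot be told apart at this position, with a 1.7-fold higher number from compound 2 to compound 3 (0.22 log units; within the scatter) as the step. Losing the trifluoromethyl therefore brings no return towards compound 1: a 23-fold higher number from compound 1 to compound 3 (1.37 log units; beyond the scatter) is a large step, so of the three groups only the one carrying 4-fluorophenyl stands apart. No supporting measurement bears on this result.

Still open, from the compounds shown here alone, is whether the hydroxyl matters, which a plain 3-phenylpropyl group would test. An unsubstituted benzyl or a 4-chlorobenzyl group would show how narrowly the fluoro substituent is tolerated.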